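Replacing Cyano with Methanesulfonamido on a Chloro Compound

A few compounds are considered here, and "the series" means these few. Any claim that something is new, unique, unknown or untested is made for them only; others in the source may bear on it.

In a functional assay on P388 cells (Mus musculus) for antiproliferative activity (on this read-out higher numbers stand for weaker inhibition and lower numbers for stronger inhibition), compound 3 `N#Cc1ccc(S(=O)(=O)Nc2cccc3c(Cl)c[nH]c23)cc1` gives 1.4 ug/mL, which places it between compound 1 `N#Cc1ccc(S(=O)(=O)Nc2cccc3cc[nH]c23)cc1` at 4.2 ug/mL and compound 2 `N#Cc1ccc(S(=O)(=O)Nc2cccc3c(C#N)c[nH]c23)cc1` at 0.53 ug/mL. The unmeasured compound 4 `CS(=O)(=O)Nc1ccc(S(=O)(=O)Nc2cccc3c(Cl)c[nH]c23)cc1` keeps the rest of compound 3 but carries methanesulfonamido in place of cyano on an aromatic carbon, para to a large group: methanesulfonamido in place of cyano on an aromatic carbon.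

Three measured steps are available, and all of them are modest. Chloro in place of hydrogen gives a 3.0-fold lower number from compound 1 to compound 3 (0.48 log units; beyond the scatter), cyano in place of hydrogen gives a 7.9-fold lower number from compound 1 to compound 2 (0.90 log units; beyond the scatter), and chloro in place of cyano gives a 2.6-fold higher number from compound 2 to compound 3 (0.42 log units; beyond the scatter). Each of these changes a different carbon from the one at issue here, and the cyano that leaves in compound 4 is present unchanged in compound 1, compound 2 and compound 3. No measurement therefore shows what replacing it does, and the steps bear only indirectly, as a guide to size. No direction can be argued from them, so the expected result is no change beyond the scatter, and the estimate is a 1.2-fold lower number from compound 3 to compound 4 (0.07 log units; within the scatter). In this assay, compound 4 is expected at 1.2 ug/mL, with an estimated range from 0.35 ug/mL to 4.5 ug/mL.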

Compound 4, half-maximal inhibitory concentration: 1.6 ug/mL
Estimate against measurement, compound 4: 1.3-fold (0.12 log units) below; the range from low to high includes it.
By their numbers in this assay, from the lowest: compound 2; then compounds 3 and 4 (each within the scatter of the next); then compound 1.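

In this assay, methanesulfonamido in place of cyano on an aromatic carbon, para to a large group, gives a 1.1-fold higher number from compound 3 to compound 4 (0.06 log units; within the scatter), so compound 3 and compound 4 cannot be told apart on this read-out. Going by these compounds alone, the earlier compounds all kept the cyano at this place and varied only another carbon, so this is the first step that reads the place itself. With the chloro compound as background, a group of 2 heavy atoms and no hydrogen-bond donor gives way to one of 5 heavy atoms with a hydrogen-bond donor, and the number stays within the scatter. Nothing measured here accounts for why the two groups read alike.

From the compounds shown here alone, it remains open whether the same exchange would read alike with cyano or hydrogen in place of the chloro, as in the backgrounds of compound 2 and compound 1, the first of which has the lowest number of the series. Going by these compounds, it is also open whether an amine, a carboxylic acid or a longer chain at this place would stay within the scatter of compound 3 or move the number clearly in either direction.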